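Adding a Third Methoxy Group: What to Expect for Compound 4

A few compounds are considered here, and "the series" means these few. Any claim that something is new, unique, unknown or untested is made for them only; others in the source may bear on it.

Three measured compounds share one core and differ only in the groups on one aromatic ring. Compound 1 `O=C(/C=C/c1ccc2c(c1)B(O)OC2)c1ccccc1` carries no methoxy group there, compound 2 `COc1ccccc1C(=O)/C=C/c1ccc2c(c1)B(O)OC2` carries one, and compound 3 `COc1ccc(C(=O)/C=C/c2ccc3c(c2)B(O)OC3)cc1OC` carries two. In a functional assay on MDA-MB-231 cells (Homo sapiens) for cytotoxicity, read by MTT assay, with a stated time of 48 h (a higher number here means a weaker inhibitor, a lower number a stronger inhibitor), compound 1 gives 2300 nM, compound 2 gives 3100 nM, and compound 3 gives 13200 nM. Compound 2 differs from compound 1 by methoxy in place of hydrogen on an aromatic carbon. The measured result was a 1.3-fold higher number from compound 1 to compound 2 (0.13 log units; within the scatter). Compound 3 gives the highest of the three numbers, beyond the scatter from both others. How the core of compound 3 differs from that of compound 1 is not broken down here.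

Compound 4 `COc1cc(C(=O)/C=C/c2ccc3c(c2)B(O)OC3)cc(OC)c1OC` is not yet measured. It arises from compound 3 by methoxy in place of hydrogen on an aromatic carbon. This is the same kind of change as the earlier one, but the surroundings differ: in compound 2 the new methoxy sits ortho to a large group, whereas in compound 4 it sits ortho to a methoxy group, meta to a large group and meta to a methoxy group. Among the compounds with values here, only one earlier step of this kind is known, and it was small. The step in this assay is expected to be a 1.4-fold higher number from compound 3 to compound 4 (0.13 log units; within the scatter), resting on that small earlier step and on the already high value of compound 3 13200 nM. Compound 4 is therefore estimated at 18000 nM, between 7000 nM and 45000 nM.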

Compound 4, half-maximal inhibitory concentration: 10600 nM
The estimate for compound 4 lay 1.7-fold (0.23 log units) above the measured number; low and high end bracket the measured number.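

In this assay the added methoxy group gives a 1.2-fold lower number from compound 3 to compound 4 (0.10 log units; within the scatter), so compound 3 and compound 4 cannot be told apart in this read-out. Set beside the earlier step, methoxy in place of hydrogen on an aromatic carbon gives no detectable difference between the two cores: the same change on two cores in this assay, a 1.3-fold higher number (0.13 log units; within the scatter) from compound 1 to compound 2 and a 1.2-fold lower number (0.10 log units; within the scatter) from compound 3 to compound 4, 1.7-fold (0.22 log units) apart, within the scatter of two such steps. This shows that, at these two places, the change left the number within the scatter on both cores, but two steps make no general rule, and it does not show what the same change would do elsewhere on the ring or on a different core.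

The compounds shown leave open whether a group other than methoxy on this ring, such as an amine, a carboxylic acid or a longer chain, would give a step beyond the scatter. They also leave open whether the methoxy change would stay this small in any read-out other than this assay.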